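Acylguanidine series: pyridyloxy in place of piperidinyl

The source may report more compounds than this note shows. Statements on the series, on what has been measured and on what is new or still open speak of the compounds shown alone.

Within the data shown here, compound 3 `CS(=O)(=O)c1cc(C(=O)N=C(N)N)ccc1N1CCCCC1` gives 130 nM in a functional assay for inhibition of sodium/hydrogen exchanger (Oryctolagus cuniculus) (on this read-out lower numbers stand for stronger inhibition and higher numbers for weaker inhibition), the lowest of the three numbers measured so far. Compound 2 `CS(=O)(=O)c1cc(C(=O)N=C(N)N)ccc1Br` gives 180 nM in this assay, and compound 1 `COc1ccc(C(=O)N=C(N)N)cc1S(C)(=O)=O` gives 270 nM. The three compounds differ only in the group on the aromatic carbon ortho to the methylsulfonyl group: a 1.5-fold lower number from compound 1 to compound 2 (0.18 log units; within the scatter); a 2.1-fold lower number from compound 1 to compound 3 (0.32 log units; beyond the scatter); a 1.4-fold lower number from compound 2 to compound 3 (0.14 log units; within the scatter). Among the measured compounds shown here, only the step from compound 1 to compound 3 falls beyond the scatter, and the whole set sits within a narrow band.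

Compound 4 `CS(=O)(=O)c1cc(C(=O)N=C(N)N)ccc1Oc1cncc(Cl)c1` continues the exchange at the same aromatic carbon: (5-chloropyridin-3-yl)oxy in place of piperidin-1-yl on an aromatic carbon. All three measured steps bear on it, as each replaces the group at this carbon, yet none brings in an aryloxy group, so the direction of the new step is not fixed by the data. Given how little the three measured exchanges moved the number, no step beyond the scatter is expected, with the estimate a 1.2-fold higher number from compound 3 to compound 4 (0.09 log units; within the scatter). Compound 4 is expected to give about 160 nM in this assay, with a range from 60 nM to 420 nM.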

Compound 4, half-maximal inhibitory concentration: 75 nM
Estimate against measurement, compound 4: 2.1-fold (0.33 log units) above, and the stated range covers the measured number.
By their numbers in this assay, from the lowest: compounds 4, 3, 2 and 1 (each within the scatter of the next, the first and the last beyond it).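

At the aromatic carbon ortho to a methylsulfonyl group, this assay accepts an aromatic ring carried on an oxygen: (5-chloropyridin-3-yl)oxy stands level with piperidin-1-yl, with a 1.7-fold lower number from compound 3 to compound 4 (0.24 log units; within the scatter) and so no order between the two. Set against bromo and methoxy, the same group reaches beyond the scatter, with a 2.4-fold lower number from compound 2 to compound 4 (0.38 log units; beyond the scatter) and with a 3.6-fold lower number from compound 1 to compound 4 (0.56 log units; beyond the scatter) as the widest step in the set. Among these compounds, compound 4 is thus the only compound here whose steps from both compound 1 and compound 2 lie beyond the scatter, whereas compound 3 does so from compound 1 only.

On these data alone, whether the ring nitrogen or the chlorine of the new group carries any of this stays open, as does the place of an unsubstituted phenoxy or a benzyloxy group at this carbon. No measurement shown here accounts for these steps.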